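The compounds below may be only part of what the source reports. "The series", "measured", "known", "first", "only" and "open" are said of these compounds alone.

Measured compounds:
compound 1 `CCOC(=O)c1sc(-c2cccc(NC(=O)c3ccccc3)c2)nc1Nc1ccc(N2CCN(C)CC2)cc1`, a functional assay on Raji cells (Homo sapiens) for antiproliferative activity, read by CCK-8 assay, with a stated time of 72 h; on this read-out higher numbers stand for weaker inhibition and lower numbers for stronger inhibition: "not determined" (no result reported)
compound 2 `CN1CCN(c2ccc(Nc3nc(-c4cccc(NC(=O)c5ccccc5)c4)sc3C(=O)O)cc2)CC1`, this assay: "not determined" (no result reported)
compound 3 `CN1CCN(c2ccc(Nc3nc(-c4cccc(NC(=O)c5ccccc5)c4)sc3C(N)=O)cc2)CC1`, this assay: 6360 nM

Three compounds share a common core and differ at the group attached to the thiophene-type ring. Among the compounds with values here, for compound 1 and compound 2 no number was reported in this assay, so compound 3 carries the only measured value: in this assay compound 3 gives 6360 nM. It therefore stands alone; no comparison with a neighbour is possible, and nothing can be said about how strongly the ester or the acid of compound 1 and compound 2 would have differed from it.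

Compound 4 `CN1CCN(c2ccc(Nc3nc(-c4cccc(NC(=O)c5ccc(C(F)(F)F)cn5)c4)sc3C(N)=O)cc2)CC1` keeps the whole of compound 3 except for one exchange: 5-(trifluoromethyl)pyridin-2-yl in place of phenyl on a carbonyl carbon. Within the data shown here, no measured pair in this set shows the effect of replacing a benzoyl group by a heteroaryl carbonyl, so the size of the step rests on general expectation only. The change is expected to produce at most a modest shift, and the step from compound 3 to compound 4 is estimated as a 1.6-fold lower number from compound 3 to compound 4 (0.20 log units; within the scatter), close to the scatter of the assay. In this assay compound 4 is expected to give about 4000 nM, with a plausible range from 1000 nM to 15000 nM.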

Compound 4, half-maximal inhibitory concentration: 24500 nM
Compound 4: the middle estimate sits 6.1-fold (0.79 log units) below what was measured; measured number above the stated range.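

Within the data shown here, this is the first step that can be read, and it concerns the group on a carbonyl carbon whose other neighbour is an amide-type nitrogen: in this assay the exchange of phenyl for 5-(trifluoromethyl)pyridin-2-yl gives a 3.9-fold higher number from compound 3 to compound 4 (0.59 log units; beyond the scatter) and so moves the read-out towards weaker inhibition by more than the scatter. The group at this position therefore matters to the result, and this particular exchange does not favour it. The ring nitrogen and the trifluoromethyl group enter together, so the step belongs to the whole new group, and no measurement given here explains the rise.

On these data alone, whether a plain pyridin-2-yl or a phenyl carrying only a trifluoromethyl group would read like compound 3 or like compound 4 remains open, as does the outcome with a cyclohexyl group or an aminomethyl-substituted phenyl on the same carbonyl. Steps involving compound 1 and compound 2 cannot be read, so the contribution of the carboxamide shared by compound 3 and compound 4 is also unsettled, as is how a nitrile or a methyl ketone would compare in its place.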